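Cytotoxicity notes on the sulfonamide ring series

The compounds below may be only part of what the source reports. "The series", "measured", "known", "first", "only" and "open" are said of these compounds alone.

Three members of this series have been tested in an ADME assay on HepG2 2.2.15 cells (Homo sapiens) for cytotoxicity, read by luminescence, with a stated time of 3 days; on this read-out higher numbers stand for lower toxicity in this test and lower numbers for higher toxicity in this test. Compound 1 `O=C(Nc1ccc(F)c(Cl)c1)c1ccc(F)c(S(=O)(=O)N2CCCCCC(O)C2)c1` gives 11000 nM. Compound 2 `O=C(Nc1ccc(F)c(Cl)c1)c1ccc(F)c(S(=O)(=O)N2CCOC[C@H](O)C2)c1` gives 19000 nM. Compound 3 `CN1CCN(S(=O)(=O)c2cc(C(=O)Nc3ccc(F)c(Cl)c3)ccc2F)CC(O)C1` gives 31000 nM. Compound 3 thus holds the highest number of the three: its nearest neighbour is compound 2, with a 1.6-fold higher number from compound 2 to compound 3 (0.21 log units; within the scatter), and its furthest is compound 1, with a 2.8-fold higher number from compound 1 to compound 3 (0.45 log units; beyond the scatter). The step of a 1.7-fold higher number from compound 1 to compound 2 (0.24 log units; within the scatter) completes the set.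

Compound 4 `CC1(O)CCCCN(S(=O)(=O)c2cc(C(=O)Nc3ccc(F)c(Cl)c3)ccc2F)C1` is not yet measured. It differs from compound 3 in one place: 3-hydroxy-3-methylazepan-1-yl in place of 6-hydroxy-4-methyl-1,4-diazepan-1-yl on a sulfonyl sulfur. The ring on the sulfonyl sulfur therefore returns to a single hetero atom, as in compound 1, while keeping the seven-membered size and the hydroxyl of compounds 2 and 3. Going by the values given here, the steps that bear on this are those of compound 1, whose ring with one hetero atom gave the lowest number, and of compounds 2 and 3, which sit within the scatter of each other. A modest move back toward compound 1 is expected, so compound 4 is estimated to show a 2.1-fold lower number from compound 3 to compound 4 (0.32 log units; beyond the scatter). Compound 4 is expected to give 15000 nM, within the range 7000 nM to 35000 nM.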

Compound 4, half-maximal cytotoxic concentration: 10000 nM
Compound 4: the middle estimate sits 1.5-fold (0.18 log units) above what was measured; low and high end bracket the measured number.
By their numbers in this assay, from the lowest: compounds 4, 1, 2 and 3 (each within the scatter of the next, the first and the last beyond it).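

In this assay, 3-hydroxy-3-methylazepan-1-yl in place of 6-hydroxy-4-methyl-1,4-diazepan-1-yl on the sulfonyl sulfur gives a 3.1-fold lower number from compound 3 to compound 4 (0.49 log units; beyond the scatter) with the seven-membered ring size and the count of 9 heavy atoms unchanged, so this position responds to the change from 2 hetero atoms to 1 hetero atom together with the shift of the methyl. Going by these compounds alone, the same group gives a 1.9-fold lower number from compound 2 to compound 4 (0.28 log units; within the scatter) against 6-hydroxy-1,4-oxazepan-4-yl and a 1.1-fold lower number from compound 1 to compound 4 (0.04 log units; within the scatter) against the eight-membered ring, both within the scatter, so ring size shows no separable step here, and compound 2, with 2 hetero atoms, goes against any clean split of the series by hetero atom count. Nothing at hand accounts for these steps.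

On these data alone, whether the step from compound 3 follows the lost ring nitrogen or the methyl on the ring carbon stays open, and a plain 3-hydroxyazepan-1-yl ring would separate the two. Also open, as far as these compounds go, is how this read-out responds to a carboxylic acid in place of the hydroxyl, or to a ring amine without the methyl.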